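The source may report more compounds than this note shows. Statements on the series, on what has been measured and on what is new or still open speak of the compounds shown alone.

Measured in a functional assay on MCF cells (Homo sapiens) for antiproliferative activity, with a stated time of 72 h; a lower number here means a stronger inhibitor, a higher number a weaker inhibitor:
- Compound 1 `OC[C@H]1O[C@@H](n2cnc3c(NCc4ccc(Cl)cc4)ncnc32)[C@H](O)[C@@H]1O`: > 166000 nM, a limit
- Compound 2 `OC[C@H]1O[C@@H](n2cnc3c(NCc4cccc(Br)c4)ncnc32)[C@H](O)[C@@H]1O`: > 166000 nM, a limit
- Compound 3 `COc1ccccc1CNc1ncnc2c1ncn2[C@@H]1O[C@H](CO)[C@@H](O)[C@H]1O`: > 166000 nM, a limit

Compound 3 gives no number, and it stands at the limit of > 166000 nM in this assay, at which 3 of the 3 values shown sit. Compound 4 `OC[C@H]1O[C@@H](n2cnc3c(NCc4ccc(Cl)c(Cl)c4)ncnc32)[C@H](O)[C@@H]1O` has not yet been measured. It keeps the shared core of compound 3 and changes one group: 3,4-dichlorophenyl in place of 2-methoxyphenyl on a saturated chain carbon bound to a nitrogen on an aromatic ring. In words, 3,4-dichlorophenyl stands in place of 2-methoxyphenyl on a saturated chain carbon bound to a nitrogen on an aromatic ring.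

For the measured compounds named here, three measured steps bear on this change: a step that the two limits leave unreadable from compound 1 to compound 3, a step that the two limits leave unreadable from compound 2 to compound 3 and a step that the two limits leave unreadable from compound 1 to compound 2. None of them has a readable size. Compound 1, with 4-chlorophenyl in the same place, stays at its limit of > 166000 nM. Compound 2, with 3-bromophenyl there, stays at its limit of > 166000 nM. No direction can be drawn from these compounds, and no change beyond the scatter is expected. The expected step is a number no higher from compound 3 to compound 4 (the limit leaves the size open). In this assay, compound 4 is estimated at 166000 nM, with an expected range from 60000 nM to 300000 nM.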

Compound 4, half-maximal inhibitory concentration: 88800 nM
Compound 4: middle estimate off by 1.9-fold (0.27 log units), on the high side; measured number inside the range.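

In this assay, compound 4 is the only one of the four compounds that gives a number, while compound 1, compound 2 and compound 3 remain at a limit: the limit of > 166000 nM in this assay, at which 3 of the 4 values shown sit.

At this place, on a saturated chain carbon bound to a nitrogen on an aromatic ring, 3,4-dichlorophenyl therefore gives the first readable steps: an at least 1.8-fold lower number from compound 3 to compound 4 (0.27 log units; that floor lies within the scatter), an at least 1.8-fold lower number from compound 2 to compound 4 (0.27 log units; that floor lies within the scatter) and an at least 1.8-fold lower number from compound 1 to compound 4 (0.27 log units; that floor lies within the scatter). Each of these is a floor within the scatter, and the steps among compound 1, compound 2 and compound 3 cannot be read.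

From the compounds shown here alone, how far the true values of those three compounds lie from that of compound 4 remains open. Also open, going by these compounds, is how this assay would respond to an amine or a carboxylic acid on the phenyl ring, or to a longer chain in place of the benzyl.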